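This account rests on a few compounds, and the source may have more. Where it says the series, first, only, none or still open, it means among the compounds named here.

Compound 3 `COc1cccc(CNCCCNc2ccnc3cc(CCC(C)C)ccc23)c1O` is one of three compounds studied in an ADME assay for permeability, using PAMPA, with a stated time of 30 min, at pH 7.4; a higher number here means that the compound crosses the layer faster, a lower number that the compound crosses the layer more slowly. In this assay compound 3 gives 23 10^-6 cm/s. Compound 2 `COc1cccc(CNCCCNc2ccnc3cc(Cc4ccccc4)ccc23)c1O` gives 23 10^-6 cm/s, and no change at the digits printed from compound 2 to compound 3 (within the scatter). Compound 1 `COc1ccc(Oc2ccc3c(NCCCNCc4cccc(OC)c4O)ccnc3c2)cc1` gives 317 10^-6 cm/s, so compound 3 sits together with compound 2 at the low end of the three numbers, and compound 1 stands farthest from it.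

The next compound, compound 4 `COc1cccc(CNCCCNc2ccnc3cc(Oc4ccccc4)ccc23)c1O`, has not yet been measured. It differs from compound 3 in one place: phenoxy in place of isopentyl on an aromatic carbon. The group that enters shares its six-membered aromatic ring and its oxygen with the 4-methoxyphenoxy group of compound 1, so the step that bears most directly on this change is a 14-fold lower number from compound 1 to compound 3 (1.14 log units; beyond the scatter). The step of no change at the digits printed from compound 2 to compound 3 (within the scatter) adds that the two chain-bound groups behave alike.

A rise in this assay is therefore expected for compound 4 because a 14-fold lower number from compound 1 to compound 3 (1.14 log units; beyond the scatter) runs the other way, though the missing methoxy leaves the size uncertain, so the expected step is a 5.2-fold higher number from compound 3 to compound 4 (0.72 log units; beyond the scatter). The estimate for compound 4 is 120 10^-6 cm/s, within a range from 40 10^-6 cm/s to 330 10^-6 cm/s.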

Compound 4, apparent permeability: 317 10^-6 cm/s
The estimate for compound 4 lay 2.6-fold (0.42 log units) below the measured number; low and high end bracket the measured number.
By their numbers in this assay, from the lowest: compounds 2 and 3 (each within the scatter of the next); then compounds 1 and 4 (each within the scatter of the next).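

At this position in this assay, phenoxy stands well apart from both isopentyl (a 14-fold higher number from compound 3 to compound 4 (1.14 log units; beyond the scatter)) and benzyl (a 14-fold higher number from compound 2 to compound 4 (1.14 log units; beyond the scatter)). Benzyl and phenoxy each carry a six-membered aromatic ring, so among these compounds the large step comes with an oxygen in place of a carbon as the link to the core. The methoxy on the outer ring of compound 1, which had left the size of the rise uncertain, does not register (no change at the digits printed from compound 1 to compound 4 (within the scatter)), and nothing shown accounts for these differences.

Going by these compounds, it remains open whether the oxygen link needs the aromatic ring at all, which a plain methoxy on the core would test. Phenylamino and phenylthio groups, which link the same ring through nitrogen or sulfur, would show whether oxygen itself matters.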